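A few compounds are considered here, and "the series" means these few. Any claim that something is new, unique, unknown or untested is made for them only; others in the source may bear on it.

In a functional assay on MDA-MB-231 cells (Homo sapiens) for cytotoxicity, read by MTT assay (a lower number here means a stronger inhibitor, a higher number a weaker inhibitor), compound 1 `COc1ccc(-c2cn(-c3cc(OC)c(OC)c(OC)c3)nn2)cc1` gives > 10000 nM, which is a limit of the assay rather than a number.
Compound 2 `COc1cc(-n2cc(-c3cc(O)cc(O)c3)nn2)cc(OC)c1OC` gives > 10000 nM in this assay, again a limit rather than a number.
Among the measured compounds shown here, compound 3 `COc1ccc(-c2cn(-c3ccc(OC(F)(F)F)cc3)nn2)cc1` gives 1000 nM in this assay, the only number among the three.

Compound 1 and compound 2 share a core and differ in one place: 3,5-dihydroxyphenyl in place of 4-methoxyphenyl on an aromatic carbon. The step that the two limits leave unreadable from compound 1 to compound 2 stays unreadable because both compounds sit at the limit of > 10000 nM in this assay, at which 2 of the 3 values shown sit. Compound 3 differs from compound 1 in more than one place, and the difference between the two cores is not broken down here.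

Compound 4 `Oc1cc(O)cc(-c2cn(-c3ccc(OC(F)(F)F)cc3)nn2)c1` has not been measured. It stands to compound 3 as compound 2 stands to compound 1: 3,5-dihydroxyphenyl in place of 4-methoxyphenyl on an aromatic carbon. The place of the change reads the same word for word, so this is the same change.

Since the measured pair gives no size, the expectation rests on compound 3 alone, whose value 1000 nM is the only foothold. The step from compound 3 to compound 4 is expected to be a 3.0-fold higher number from compound 3 to compound 4 (0.48 log units; beyond the scatter). Compound 4 is thus estimated at 3000 nM, with a likely range from 800 nM to 15000 nM.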

Compound 4, half-maximal inhibitory concentration: > 10000 nM
Compound 4 gave a limit, no number; the forecaster's own chance of this, stated with the estimate: 30%; middle value at least 3.3-fold (0.52 log units) away from the limit.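

Where the starting compound gives a readable number, the change from 4-methoxyphenyl to 3,5-dihydroxyphenyl makes the compound clearly weaker in this assay, with an at least 10-fold higher number from compound 3 to compound 4 (1.00 log units; beyond the scatter). Compound 4 gives > 10000 nM, which is a limit of the assay and not a number, so the true size of this step could be larger than the printed minimum. The same change from compound 1 to compound 2 cannot be read, so the series shows that the change costs activity on one core but not that its size carries over from one core to the other, because the values stop at the same ceiling: the limit of > 10000 nM in this assay, at which 3 of the 4 values shown sit.

The compounds shown leave open whether a single hydroxy group, an amine or a carboxylic acid on that phenyl ring would keep a readable number on the core of compound 3. They also leave open whether a methoxy group at the 3 and 5 positions of that ring would behave like the two hydroxy groups.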